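A few compounds are considered here, and "the series" means these few. Any claim that something is new, unique, unknown or untested is made for them only; others in the source may bear on it.

Measured compounds:
- compound 1 `COc1cc2c(Oc3ccc(NC(=O)c4nn(-c5ccccc5C(F)(F)F)c(=O)cc4C)cc3F)ccnc2cc1OCCCN1CCC(C)CC1`: in a functional assay on NCI-H460 cells (Homo sapiens) for inhibition, read by MTT assay, with a stated time of 72 h (on this read-out higher numbers stand for weaker inhibition and lower numbers for stronger inhibition), compound 1 gives 200 nM
- compound 2 `COc1cc2c(Oc3ccc(NC(=O)c4nn(-c5ccccc5C(F)(F)F)c(=O)cc4C)cc3F)ccnc2cc1OCCCN1CCN(C)CC1`: in this assay compound 2 gives 240 nM
- compound 3 `COc1ccc(-n2nc(C(=O)Nc3ccc(Oc4ccnc5cc(OCCCN6CCC(C)CC6)c(OC)cc45)c(F)c3)c(C)cc2=O)cc1`: in this assay compound 3 gives 4650 nM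

Compound 4 `COc1ccc(-n2nc(C(=O)Nc3ccc(Oc4ccnc5cc(OCCCN6CCN(C)CC6)c(OC)cc45)c(F)c3)c(C)cc2=O)cc1` is not yet measured in this assay.

Compounds 1 and 2 differ by 4-methylpiperazin-1-yl in place of 4-methylpiperidin-1-yl on a saturated chain carbon, three bonds along the chain from an oxygen on an aromatic ring. The step that this change made is a 1.2-fold higher number from compound 1 to compound 2 (0.08 log units; within the scatter), so the two values are not separable here.

Compounds 3 and 4 differ by 4-methylpiperazin-1-yl in place of 4-methylpiperidin-1-yl on a saturated chain carbon, three bonds along the chain from an oxygen on an aromatic ring. The place line reads the same word for word as for the pair of compounds 1 and 2, so this is the same change, now made on the core of compound 3 rather than the core of compound 1. The two cores differ by 4-methoxyphenyl in place of 2-(trifluoromethyl)phenyl on an aromatic nitrogen, a change that made a 23-fold higher number from compound 1 to compound 3 (1.37 log units; beyond the scatter), which puts compound 3 at the weak end of the three numbers.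

Whether the piperazine-for-piperidine exchange behaves alike on the weaker core is not shown by any other pair. Resting on the one precedent, the step from compound 3 to compound 4 in this assay is expected to be a 1.2-fold higher number from compound 3 to compound 4 (0.07 log units; within the scatter), because compound 1 to compound 2 gave a 1.2-fold higher number from compound 1 to compound 2 (0.08 log units; within the scatter). Compound 4 is therefore estimated at 5500 nM, with 2500 nM to 12000 nM as the expected range.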

Compound 4, half-maximal inhibitory concentration: 3660 nM
Compound 4: middle estimate off by 1.5-fold (0.18 log units), on the high side, and the stated range covers the measured number.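

In this assay, 4-methylpiperazin-1-yl in place of 4-methylpiperidin-1-yl gives a 1.3-fold lower number from compound 3 to compound 4 (0.10 log units; within the scatter), so on both cores the exchange stays within the scatter and the two steps do not differ: the same change on two cores in this assay, a 1.2-fold higher number (0.08 log units; within the scatter) from compound 1 to compound 2 and a 1.3-fold lower number (0.10 log units; within the scatter) from compound 3 to compound 4, 1.5-fold (0.18 log units) apart, within the scatter of two such steps

Read on the 4-methylpiperazin-1-yl side, 4-methoxyphenyl in place of 2-(trifluoromethyl)phenyl on the aromatic nitrogen gives a 15-fold higher number from compound 2 to compound 4 (1.18 log units; beyond the scatter), and this large step also carries over between the two cores: the same change on two cores in this assay, a 23-fold higher number (1.37 log units; beyond the scatter) from compound 1 to compound 3 and a 15-fold higher number (1.18 log units; beyond the scatter) from compound 2 to compound 4, 1.5-fold (0.18 log units) apart, within the scatter of two such steps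

In this four-compound square the two changes therefore read as independent, but that rests on one cell assay and one pair of groups at each place, and it shows neither that the independence extends to other groups nor what lies behind the large step.

The compounds shown leave open where a plain phenyl or a 2-chlorophenyl on the aromatic nitrogen would fall relative to the two groups compared here. They also leave open whether a morpholine or a shorter ethyl chain at the other place would stay as silent as the exchange seen here.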